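The compounds below may be only part of what the source reports. "The series", "measured", "known", "first", "only" and "open" are said of these compounds alone.

Compound 1: `OC(c1ncccc1F)C1(c2ccc(Cl)c(Cl)c2)CCC1` with 610 nM
Compound 2: `C[C@]1(O)C[C@](c2ccnc(C(F)(F)F)c2)([C@H](O)c2ccccn2)C1` with 500 nM
Compound 3: `O[C@H](c1ccccn1)[C@]1(c2ccnc(C(F)(F)F)c2)C[C@H](O)C1` with 60 nM

The three compounds were tested in an assay on HEK293 cells for antagonist activity at transient receptor potential cation channel subfamily V member 3 (Homo sapiens), read by FLIPR and calcium flux; on this read-out higher numbers stand for weaker inhibition and lower numbers for stronger inhibition. Compound 3 gives the lowest number of the three, in this assay reaching 60 nM. Its nearest neighbour is compound 2, which gives 500 nM, and compound 1, which gives 610 nM, lies furthest away. Within the data shown here, the only step between two compounds that differ in a single place is an 8.3-fold lower number from compound 2 to compound 3 (0.92 log units; beyond the scatter), a change of hydrogen in place of methyl on a saturated ring carbon.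

Compound 4, `O[C@H](c1ccccn1)[C@]1(c2ccnc(C(F)(F)F)c2)C[C@@H](O)C1`, has not yet been measured. It differs from compound 3 as follows: the two compounds have the same atoms and bonds and differ only in configuration as drawn: 2 of 3 stereo elements differ; a stereocentre at a saturated ring carbon is drawn s in compound 3 and r in compound 4; a stereocentre at a saturated ring carbon is drawn R in compound 3 and S in compound 4. So the two share every atom and bond and differ only in the arrangement in space at two saturated ring carbons. Among the measured compounds shown here, none of the measured steps concerns such a change, since the step from compound 2 to compound 3 swaps a group rather than turning one. Compounds that differ only in this way commonly give numbers some way apart, but the direction cannot be read from the data shown. Compound 4 is therefore expected to give a somewhat higher number than compound 3, a step of a 2.5-fold higher number from compound 3 to compound 4 (0.40 log units; beyond the scatter), with wide uncertainty. The estimate for compound 4 in this assay is 150 nM, within a range of 40 nM to 600 nM.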

Compound 4, antagonist equilibrium constant: 530 nM
Beside the measured number, compound 4's estimate is 3.5-fold (0.55 log units) below it; the range from low to high includes it.
By their numbers in this assay, from the lowest: compound 3; then compounds 2, 4 and 1 (each within the scatter of the next).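

Compounds 3 and 4 contain the same atoms and bonds, yet this assay separates them clearly, with an 8.8-fold higher number from compound 3 to compound 4 (0.95 log units; beyond the scatter). Among these compounds, until now, the only measured change was a swap of one group for another, an 8.3-fold lower number from compound 2 to compound 3 (0.92 log units; beyond the scatter), so the earlier compounds could not show that the spatial arrangement at these saturated ring carbons matters on its own; here, a change with nothing added or removed produces a step of similar size to that swap. The difference can be assigned to configuration alone because nothing else separates the pair: the fact that compounds 3 and 4 differ only in the configuration as drawn.

As far as these compounds go, two of the three stereo elements differ together, so these compounds do not show whether one of those ring carbons accounts for most of the step or whether both contribute, and the cause of the preference at the level of the molecule remains unknown. From the compounds shown here alone, it also remains open whether the same preference for the arrangement in compound 3 would hold with an amine or a methoxy group in place of the hydroxyl group on the saturated ring carbon.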